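Changing the side chain on a weakly active core

The compounds below may be only part of what the source reports. "The series", "measured", "known", "first", "only" and "open" are said of these compounds alone.

Compound 3 `CCCSc1nc(Cl)c2c(n1)N(CCNC(=O)OC(C)(C)C)C(C(=O)N1CCN(C)CC1)N2` belongs to a small set sharing one core and differing only in the group on a saturated chain carbon bound to a nitrogen on an aromatic ring in a ring. In a functional assay on TE-1 cells (Homo sapiens) for antiproliferative activity, read by MTT assay, with a stated time of 72 h (a lower number here means a stronger inhibitor, a higher number a weaker inhibitor), compound 3 gives 51800 nM, a number that sits within the scatter of what compound 2 `CCCSc1nc(Cl)c2c(n1)N(Cc1ccccc1)C(C(=O)N1CCN(C)CC1)N2` gives, 42500 nM. Compound 1 `CCCSc1nc(Cl)c2c(n1)N(CC1CCCCC1)C(C(=O)N1CCN(C)CC1)N2` reaches only a limit of the assay, > 64000 nM (the limit of > 64000 nM in this assay, at which 1 of the 3 values shown sits). The steps of an at least 1.5-fold lower number from compound 1 to compound 2 (0.17 log units; that floor lies within the scatter), an at least 1.2-fold lower number from compound 1 to compound 3 (0.09 log units; that floor lies within the scatter) and a 1.2-fold higher number from compound 2 to compound 3 (0.09 log units; within the scatter) all stay inside the scatter. Compound 4 `CCCSc1nc(Cl)c2c(n1)N(Cc1ccco1)C(C(=O)N1CCN(C)CC1)N2` carries furan-2-yl in place of ((tert-butoxycarbonyl)amino)methyl on a saturated chain carbon bound to a nitrogen on an aromatic ring in a ring. Since every measured exchange at this place stayed within the scatter, no step beyond it is expected, and the estimated step is a 1.2-fold lower number from compound 3 to compound 4 (0.06 log units; within the scatter). Compound 4 is therefore expected near 45000 nM, between 20000 nM and 90000 nM.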

Compound 4, half-maximal inhibitory concentration: 35000 nM
Compound 4: middle estimate off by 1.3-fold (0.11 log units), on the high side; the range from low to high includes it.
By their numbers in this assay, from the lowest: compounds 4, 2 and 3 (each within the scatter of the next). At a limit, above all of these: compound 1.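

With furan-2-yl at this place, this assay shows that losing the hydrogen-bond donor of the chain leaves the result inside the scatter, a 1.5-fold lower number from compound 3 to compound 4 (0.17 log units; within the scatter), and that the five-membered aromatic ring with its hetero atom does the same against phenyl, a 1.2-fold lower number from compound 2 to compound 4 (0.08 log units; within the scatter). Against cyclohexyl the step, an at least 1.8-fold lower number from compound 1 to compound 4 (0.26 log units; that floor lies within the scatter), is only a floor and does not give the true size of the difference. Compound 1 stands at a limit: the limit of > 64000 nM in this assay, at which 1 of the 4 values shown sits.

Going by these compounds, whether any group here can move the number beyond the scatter stays open. A free amine, a carboxylic acid or a longer chain on this carbon would test that.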